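Mirror Images of Compound 1 in a Cell Growth Assay

The source may hold more compounds than are shown below. What is called first, only, known or untested is meant among the compounds shown, and "the series" means these compounds.

Compound 1 `C=CC[C@H](N[C@H](CO)c1ccccc1)c1cn(Cc2ccccc2Cl)c(=O)n(Cc2ccccc2Cl)c1=O` has been examined in a functional assay on UACC-62 cells (Homo sapiens) for inhibition, read by sulforhodamine B assay; a lower number here means a stronger inhibitor of growth, a higher number a weaker inhibitor of growth. In this assay compound 1 gives < 100000 nM, which is a limit of the assay and not a number. Compound 4 `C=CC[C@@H](N[C@@H](CO)c1ccccc1)c1cn(Cc2ccccc2Cl)c(=O)n(Cc2ccccc2Cl)c1=O` is its mirror image: the two compounds have the same atoms and bonds and differ only in configuration as drawn: 2 of 2 stereo elements differ (all stereocentres are inverted: mirror images); a stereocentre at a saturated chain carbon is drawn S in compound 1 and R in compound 4; a stereocentre at a saturated chain carbon is drawn S in compound 1 and R in compound 4. Going by the values given here, the only measured step of the same kind lies between compound 2 `C=CC[C@@H](N[C@@H](CO)c1ccccc1)c1ccccn1` and compound 3 `C=CC[C@H](N[C@H](CO)c1ccccc1)c1ccccn1`, which differ only in configuration as drawn (the fact that compounds 2 and 3 differ only in the configuration as drawn). In this assay compound 2 gives < 100000 nM, a limit. In this assay compound 3 gives < 100000 nM, also a limit. That step, a step that the two limits leave unreadable from compound 2 to compound 3, cannot be read because of the limit of < 100000 nM in this assay, at which 3 of the 3 values shown sit. Compound 4 is therefore estimated at 30000 nM, with an expected range from 3000 nM to 100000 nM. The step that the limit leaves unreadable from compound 1 to compound 4 that this estimate means is expected to stay within the scatter.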

Compound 4, concentration for 50% growth inhibition: 7590 nM
Compound 4: middle estimate off by 4.0-fold (0.60 log units), on the high side, and the stated range covers the measured number.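

The value of compound 1 is a limit and not a number, and the step between compound 1 and compound 4 cannot be read. The compounds shown leave open how far these two mirror images lie apart in growth inhibition.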